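Trifluoromethyl in Place of Nitro on an Isomerase Inhibitor

The source may report more compounds than this note shows. Statements on the series, on what has been measured and on what is new or still open speak of the compounds shown alone.

Measured compounds:
compound 1 `O=[N+]([O-])c1ccc(C(c2c(O)ccc3[nH]ncc23)N2CCCCC2)cc1`: 520 nM
compound 2 `Oc1ccc2[nH]ccc2c1C(c1ccc(F)cc1)N1CCCCC1`: 1810 nM
compound 3 `Cc1ccnc(NC(c2ccc3cccnc3c2O)c2c(Cl)cccc2Cl)c1`: > 40000 nM

In an assay for inhibition of protein disulfide-isomerase (Homo sapiens), with a stated time of 1 h (on this read-out lower numbers stand for stronger inhibition and higher numbers for weaker inhibition), compound 1 gives 520 nM, the lowest of the two numbers shown. The nearest is compound 2 at 1810 nM, a gap beyond the usual scatter. For compound 3 this assay reports only a limit, > 40000 nM, as noted in the limit of > 40000 nM in this assay, at which 1 of the 3 values shown sits.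

Compound 4 `Oc1ccc2[nH]ncc2c1C(c1ccc(C(F)(F)F)cc1)N1CCCCC1` differs from compound 1 in one place: trifluoromethyl in place of nitro on an aromatic carbon. Among the measured compounds shown here, no step between measured compounds of this kind is available, so the size of the change is an expectation only. A modest weakening in this assay is expected, a 1.9-fold higher number from compound 1 to compound 4 (0.28 log units; within the scatter). Compound 4 is expected to give about 1000 nM, with a range from 300 nM to 4000 nM.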

Compound 4, half-maximal inhibitory concentration: 710 nM
The estimate for compound 4 lay 1.4-fold (0.15 log units) above the measured number; measured number inside the range.
By their numbers in this assay, from the lowest: compounds 1 and 4 (each within the scatter of the next); then compound 2. At a limit, above all of these: compound 3.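

In this assay, trifluoromethyl in place of nitro on an aromatic carbon, para to a large group, gives a 1.4-fold higher number from compound 1 to compound 4 (0.14 log units; within the scatter), so on this core the nitro group is not required to keep the number at this level. Among the compounds shown here, none of the earlier compounds formed a step at this position, which makes this the only direct reading of it. Nothing shown gives a cause for this result. From the compounds shown here alone, how a nitrile, a methoxy group or an amine would read at this position stays open. So does whether the same exchange would give a similar result on another core.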